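The source may hold more compounds than are shown below. What is called first, only, known or untested is meant among the compounds shown, and "the series" means these compounds.

Measured in a functional assay on HEK293 cells for agonist activity at Toll-like receptor 8 (Homo sapiens), read by reporter gene assay; on this read-out higher numbers stand for an effect only at larger amounts of compound and lower numbers for an effect already at smaller amounts:
compound 1 `CCCCCNc1oc2c(C)ncc(CO)c2c1Nc1ccccn1`: 5810 nM
compound 2 `Cc1ncc(CO)c2c(Nc3ccccn3)c(NC(C)(C)CC(C)(C)C)oc12`: "not active" (no number reported), no number reported
compound 3 `Cc1ncc(CO)c2c(Nc3ccccn3)c(N[C@@H](C)c3ccccc3)oc12`: 4270 nM

Compound 3 stands at the lower of the two numbers reported in this assay; the nearest is compound 1, and the step of a 1.4-fold lower number from compound 1 to compound 3 (0.13 log units; within the scatter) lies within the scatter, so no order between the two is claimed. Compound 2 gives no number at all in this assay.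

Compound 4 `Cc1ncc(CO)c2c(Nc3ccccn3)c(NCCC(=O)OC(C)(C)C)oc12` differs from compound 3 in one place: 2-(tert-butoxycarbonyl)ethyl in place of 1-phenylethyl on a nitrogen on an aromatic ring. Among the compounds with values here, the only measured step that bears on this position is a 1.4-fold lower number from compound 1 to compound 3 (0.13 log units; within the scatter), an exchange of one chain for another on the same nitrogen that stayed within the scatter. Within the data shown here, compound 2 shows that an exchange at this position can also remove the measurable effect, but no step to compound 2 is computed, so its weight is uncertain. Among the measured compounds shown here, from the one measured step, no change beyond the scatter is expected for compound 4 in this assay. The upper end of the range is set wide because compound 2 gives "not active" (no number reported). For compound 4 the expected value is 6000 nM, within 2500 nM to 20000 nM. This estimate means the step of a 1.4-fold higher number from compound 3 to compound 4 (0.15 log units; within the scatter).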

Compound 4, half-maximal effective concentration: 7640 nM
Compound 4: the middle estimate sits 1.3-fold (0.10 log units) below what was measured; measured number inside the range.
By their numbers in this assay, from the lowest: compounds 3, 1 and 4 (each within the scatter of the next).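

In this assay, the nitrogen on an aromatic ring now carries a chain with no ring and with hydrogen-bond acceptors, and 2-(tert-butoxycarbonyl)ethyl in place of 1-phenylethyl gives a 1.8-fold higher number from compound 3 to compound 4 (0.25 log units; within the scatter) and so does not separate the two compounds, although the entering group has lost the six-membered aromatic ring and the defined stereocentre. Tert-butoxycarbonyl in place of propyl on the saturated chain carbon, two bonds along the chain from a nitrogen on an aromatic ring, gives a 1.3-fold higher number from compound 1 to compound 4 (0.12 log units; within the scatter), so compound 1, compound 3 and compound 4 cannot be told apart in this read-out, and compound 2, reported as "not active", stands against any claim that every group at this position is equivalent. No accompanying evidence bears on this result.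

Going by these compounds, whether a carboxylic acid in place of the tert-butyl ester, an amine at the chain end or a longer chain would stay within the scatter of compound 4 remains open. Also open, on these data alone, is what separates compound 2 from the three compounds that give numbers, since it is the only entry at this position without one.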